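Ethylsulfanyl to Butylamino on the Shared Core

The source may hold more compounds than are shown below. What is called first, only, known or untested is meant among the compounds shown, and "the series" means these compounds.

Compound 1 `CCSc1nc(N)c2nc(O)n(Cc3ccccc3)c2n1` stands lowest of the three compounds measured in a functional assay (spleen, spleen) for activation, with Mus musculus as the target (on this read-out lower numbers stand for an effect already at smaller amounts and higher numbers for an effect only at larger amounts of compound), where compound 1 gives 0.1 uM. Compound 2 `Cc1ccc(Cn2c(O)nc3c(N)ncnc32)cc1` gives 10 uM in this assay, and compound 3 `Nc1ncnc2c1nc(O)n2Cc1ccc(Cl)cc1` gives 10 uM, both well beyond the scatter above compound 1. Within the data shown here, the only measured step, no change at the digits printed from compound 2 to compound 3 (within the scatter), concerns a different aromatic carbon and does not touch the place at which compound 4 `CCCCNc1nc(N)c2nc(O)n(Cc3ccccc3)c2n1` differs from compound 1: butylamino in place of ethylsulfanyl on an aromatic carbon. Among the measured compounds shown here, no measured step bears on this change, so no step beyond the scatter is expected in this assay. Compound 4 is therefore estimated to give 0.15 uM, with a range from 0.03 uM to 1 uM. The expected step is a 1.5-fold higher number from compound 1 to compound 4 (0.18 log units; within the scatter).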

Compound 4, minimum effective concentration: 1 uM
The estimate for compound 4 lay 6.7-fold (0.82 log units) below the measured number; the range from low to high includes it.
By their numbers in this assay, from the lowest: compound 1; then compound 4; then compounds 2 and 3 (each within the scatter of the next).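

In this assay, among these compounds, butylamino in place of ethylsulfanyl gives a 10-fold higher number from compound 1 to compound 4 (1.00 log units; beyond the scatter) and so shows, as no earlier step could, that this position between two ring nitrogen atoms responds to the group it carries. The exchange changes both the chain and its linking atom, and the entering group brings a hydrogen-bond donor that ethylsulfanyl lacks. Nothing available explains the step. The compounds shown do not separate the effect of the linking atom from that of the chain length. Ethylamino or butylsulfanyl at this position would pull the two apart.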